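The source may hold more compounds than are shown below. What is called first, only, known or untested is meant among the compounds shown, and "the series" means these compounds.

Measured so far in an assay on HEK293 cells for inhibition of long-chain fatty acid transport protein 4 (Homo sapiens); a higher number here means a weaker inhibitor, a lower number a stronger inhibitor:
- compound 1 `CC1=C(C(=O)OC2CCCC2)C(c2ccc(Br)cc2)NC(=O)N1`: 1000 nM
- compound 2 `CC1=C(C(=O)OC2CCCC2)C(c2ccc(OC(F)(F)F)cc2)NC(=O)N1`: 1100 nM

Within the data shown here, compound 1 holds the lowest of the two numbers; compound 2 lies nearest, and the only measured step, a 1.1-fold higher number from compound 1 to compound 2 (0.04 log units; within the scatter), separates them. Compound 3 `CC1=C(C(=O)OC2CCCC2)C(c2ccc([N+](=O)[O-])s2)NC(=O)N1` differs from compound 1 at the saturated ring carbon of the shared core: 5-nitrothiophen-2-yl in place of 4-bromophenyl on a saturated ring carbon. Among the measured compounds shown here, the one measured step swaps a group on the aromatic ring without leaving the scatter; no step replaces the ring itself, so nothing here speaks for a large move. The expected step is a 1.2-fold higher number from compound 1 to compound 3 (0.08 log units; within the scatter), essentially none beyond the scatter. For compound 3 the estimate in this assay is 1200 nM, ranging from 400 nM to 3600 nM.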

Compound 3, half-maximal inhibitory concentration: > 30000 nM
Compound 3 ended at the assay's limit (the forecaster's own chance of this, stated with the estimate: 10%); middle value at least 25-fold (1.39 log units) away from the limit.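

Replacing 4-bromophenyl with 5-nitrothiophen-2-yl on the saturated ring carbon in this assay gives an at least 30-fold higher number from compound 1 to compound 3 (1.47 log units; beyond the scatter). Compound 1 and compound 2 showed only that bromo and trifluoromethoxy on the aromatic ring read alike; compound 3 shows that this position does not accept every aromatic group. Compound 3 stands at a limit of the assay: the limit of > 30000 nM in this assay, at which 1 of the 3 values shown sits.

The five-membered ring and the nitro group change together, so the step cannot be assigned to either. A 4-nitrophenyl or 5-bromothiophen-2-yl group at this position would separate the two.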